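Removing the phenoxy group from compound 2: expected cytotoxicity

This account rests on a few compounds, and the source may have more. Where it says the series, first, only, none or still open, it means among the compounds named here.

Compound 1, `O=C(NCc1ccc(F)cc1)c1nc(NCCO)c2cccnc2c1O`, in a functional assay on MDA-MB-435 cells (Homo sapiens) for cytotoxicity, read by MTT assay, with a stated time of 72 h (a higher number here means a weaker inhibitor, a lower number a stronger inhibitor), gives > 20000 nM, which is a limit of the assay and not a number. Compound 2, `N[C@H]1CC[C@H](Nc2c(C(=O)NCc3ccc(Oc4ccccc4)cc3)nc(Br)c3cccnc23)CC1`, in this assay gives 4000 nM. Compound 3, `C[C@H](Nc1c(C(=O)NCc2ccc(F)cc2)nc(Br)c2cccnc12)c1ccccc1`, in this assay gives > 20000 nM, again a limit of the assay.

For the measured compounds named here, compound 2 therefore stands as the only member of the series with a measured number; the other two values are limits, as the limit of > 20000 nM in this assay, at which 2 of the 3 values shown sit, states. Going by the values given here, no two measured compounds differ in a single place, so no measured step is available for comparison.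

The next compound, compound 4, `N[C@H]1CC[C@H](Nc2c(C(=O)NCc3ccccc3)nc(Br)c3cccnc23)CC1`, differs from compound 2 at one place: hydrogen in place of phenoxy on an aromatic carbon. Among the compounds with values here, since no measured step bears on this change, the expectation rests on the single number of compound 2 and on the fact that the remaining compounds sit at the assay limit. A weakening beyond the usual scatter is expected, so that the estimated step of a 3.0-fold higher number from compound 2 to compound 4 (0.48 log units; beyond the scatter) points toward weaker inhibition. For compound 4 the expected value in this assay is 12000 nM, with a range from 4000 nM to 40000 nM, and a real chance that only a limit is reported.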

Compound 4, half-maximal inhibitory concentration: 7000 nM
Compound 4: middle estimate off by 1.7-fold (0.23 log units), on the high side; measured number inside the range.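

Working notes on the para position of the aromatic ring carried by the amide: in this assay, hydrogen in place of phenoxy gives a 1.8-fold higher number from compound 2 to compound 4 (0.24 log units; within the scatter). For the compounds shown here, this is the first measured step, and it shows that, for this pair, a whole six-membered aromatic ring of carbon only can leave this aromatic carbon without a shift beyond the scatter. Compound 4 also gives a number rather than a limit of the assay, so a measured reading on the shared core does not depend on the phenoxy group, although this rests on one pair only.

Going by these compounds alone, compound 1 and compound 3 remain limits of the assay, not numbers, and no single-place step connects either of them to the pair, so the series still has only one readable step: the limit of > 20000 nM in this assay, at which 2 of the 4 values shown sit. Open, on these data alone, is what a methoxy group, a carboxylic acid or an amine would give on this same aromatic carbon, and whether any group there can move the reading beyond the scatter in either direction.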